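A few compounds are considered here, and "the series" means these few. Any claim that something is new, unique, unknown or untested is made for them only; others in the source may bear on it.

In an ADME assay on MT4 cells (Homo sapiens) for cytotoxicity, read by MTT assay (on this read-out higher numbers stand for lower toxicity in this test and lower numbers for higher toxicity in this test), three compounds built on one shared core have been measured so far. Compound 1 (`O=C1c2ccccc2C(=O)N1CCOC(=S)N(C(=O)c1ccccc1[N+](=O)[O-])c1ccc(Cl)cc1`) gives 21000 nM in this test, and compound 2 (`O=C1c2ccccc2C(=O)N1CCOC(=S)N(C(=O)c1cccc([N+](=O)[O-])c1)c1ccc(Cl)cc1`) gives 18000 nM in the same test. Compound 3 (`O=C1c2ccccc2C(=O)N1CCOC(=S)N(C(=O)c1ccc(C(F)(F)F)cc1)c1ccc(Cl)cc1`) gives 10000 nM and so stands at the low end of the three. The measurements show a 2.1-fold lower number from compound 1 to compound 3 (0.32 log units; beyond the scatter) and also a 1.8-fold lower number from compound 2 to compound 3 (0.26 log units; within the scatter) on the way to it.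

The next compound, compound 4 (`O=C1c2ccccc2C(=O)N1CCOC(=S)N(C(=O)c1ccc([N+](=O)[O-])cc1)c1ccc(Cl)cc1`), differs from compound 3 in one place: nitro in place of trifluoromethyl on an aromatic carbon in this change, which is nitro in place of trifluoromethyl on an aromatic carbon.

Compound 1 and compound 2 also carry a nitro group on that aromatic ring, though at other places, and the step between them is small: a 1.2-fold lower number from compound 1 to compound 2 (0.07 log units; within the scatter) for that move. The two steps to compound 3 are the closest guide, since each swaps a nitro-bearing ring for the ring of compound 3. Read backwards, they suggest only a small move toward higher numbers, probably inside the scatter.

The expected step is a 1.6-fold higher number from compound 3 to compound 4 (0.20 log units; within the scatter) in this assay as estimated here. Compound 4 is estimated at 16000 nM, with an expected range from 8000 nM to 30000 nM for repeat measurements.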

Compound 4, half-maximal cytotoxic concentration: > 100000 nM
Compound 4: a limit, no number; the forecaster's own chance of this, stated with the estimate: 5%; middle value at least 6.2-fold (0.79 log units) from the limit.
By their numbers in this assay, from the lowest: compounds 3, 2 and 1 (each within the scatter of the next, the first and the last beyond it). At a limit, above all of these: compound 4.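

Compound 4 gives no number in this assay, only a limit: the limit of > 100000 nM in this assay, at which 1 of the 4 values shown sits. Even with a limit, the step can be read, and an at least 10-fold higher number from compound 3 to compound 4 (1.00 log units; beyond the scatter) shows that the group on this aromatic carbon, para to a large group, can shift the read-out strongly toward lower toxicity in this test, a reach that the steps among the earlier compounds did not show. The place of the nitro also counts: the 4-nitrophenyl group gives an at least 5.5-fold higher number from compound 2 to compound 4 (0.74 log units; beyond the scatter) and an at least 4.7-fold higher number from compound 1 to compound 4 (0.67 log units; beyond the scatter), whereas the 2-nitrophenyl and 3-nitrophenyl groups differ little, with a 1.2-fold lower number from compound 1 to compound 2 (0.07 log units; within the scatter).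

From the compounds shown here alone, the true size of all three new steps stays open, since each one starts or ends at a limit and so gives only a minimum. Going by these compounds, it also stays open whether other groups at this same place, such as an amine, a nitrile or a carboxylic acid, would give a number as high as the nitro group does, or would stay closer to compound 3.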